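The source may report more compounds than this note shows. Statements on the series, on what has been measured and on what is new or still open speak of the compounds shown alone.

In an ADME assay on WI-38 cells (Homo sapiens) for cytotoxicity, read by MTT assay, with a stated time of 72 h (on this read-out lower numbers stand for stronger inhibition and higher numbers for weaker inhibition), compound 1 (`CCNC(=O)CCc1cccc2c1B(O)OC2`) gives > 100000 nM, which is a limit of the assay and not a number. Compound 2 (`O=C(CCc1cccc2c1B(O)OC2)NCc1ccccc1`) gives > 100000 nM, which is also a limit. Compound 2 therefore has no number of its own and stands with compound 1 at the limit of > 100000 nM in this assay, at which 2 of the 2 values shown sit. Compound 3 (`O=C(CCc1cccc2c1B(O)OC2)Nc1ccc(F)cc1`) has 4-fluorophenyl in place of benzyl on an amide-type nitrogen. Among the compounds with values here, only one measured step bears on this change, a step that the two limits leave unreadable from compound 1 to compound 2, and it concerns a different place, a saturated chain carbon bound to an amide-type nitrogen. Resting on that single step of unreadable size, no step beyond the scatter is expected, and another limit is the likeliest report. The estimated change is a number no higher from compound 2 to compound 3 (the limit leaves the size open). For compound 3 the expected value is 100000 nM, with an estimated range from 40000 nM to 200000 nM.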

Compound 3, half-maximal inhibitory concentration: 12000 nM
Compound 3: middle estimate off by 8.3-fold (0.92 log units), on the high side; measured number outside the range, below it.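

On the amide-type nitrogen, the substituent turns out to matter in this assay: 4-fluorophenyl in place of benzyl gives an at least 8.3-fold lower number from compound 2 to compound 3 (0.92 log units; beyond the scatter), and 4-fluorophenyl in place of ethyl gives an at least 8.3-fold lower number from compound 1 to compound 3 (0.92 log units; beyond the scatter). Within the data shown here, these are the first readable steps, and both are lower bounds on the true size, so the full size of the change stays unknown. Compound 3 is the only compound here with a number of its own, and compounds 1 and 2 remain at a limit of the assay: the limit of > 100000 nM in this assay, at which 2 of the 3 values shown sit.

The compounds shown do not separate the part played by the fluorine from that of the ring standing on the amide-type nitrogen in place of benzyl. Plain phenyl or 4-chlorophenyl at this place would bear on that, and how far the number can fall remains open.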